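Cytotoxicity notes: aryl amides on a shared thiazole-pyridine core

A few compounds are considered here, and "the series" means these few. Any claim that something is new, unique, unknown or untested is made for them only; others in the source may bear on it.

Compound 2 `O=C(Nc1nc(-c2ccccn2)cs1)c1ccc(Br)cc1` has the higher of the two numbers in an ADME assay on Vero cells (Chlorocebus sabaeus) for cytotoxicity, read by MTT assay, with a stated time of 72 h (a lower number here means that less compound is needed, a higher number that more compound is needed for the effect), giving 4700 nM; its neighbour compound 1 `O=C(Nc1nc(-c2ccccn2)cs1)c1ccc(OCc2ccccc2)cc1` gives 2300 nM there. Within the data shown here, the one measured step, a 2.0-fold higher number from compound 1 to compound 2 (0.31 log units; beyond the scatter), shows a modest shift. Compound 3 `O=C(Nc1nc(-c2ccccn2)cs1)c1ccccn1` carries pyridin-2-yl in place of 4-bromophenyl on a carbonyl carbon. Among the measured compounds shown here, no measured step covers this change, so the estimate leans on the small spread seen so far, and the step of a 1.1-fold higher number from compound 2 to compound 3 (0.03 log units; within the scatter) is expected to stay within the scatter. Compound 3 is therefore estimated at 5000 nM, with a range from 2000 nM to 12000 nM.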

Compound 3, half-maximal effective concentration: 5400 nM
Compound 3: the middle estimate sits 1.1-fold (0.03 log units) below what was measured; low and high end bracket the measured number.
By their numbers in this assay, from the lowest: compound 1; then compounds 2 and 3 (each within the scatter of the next).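

On the carbonyl carbon, pyridin-2-yl in place of 4-bromophenyl gives a 1.1-fold higher number from compound 2 to compound 3 (0.06 log units; within the scatter) in this assay, so a ring with one hetero atom and a hydrogen-bond acceptor reads the same here as a carbon-only ring. Unlike the step from benzyloxy to bromo, this step stays within the scatter. Nothing available accounts for this result.

Still open, as far as these compounds go, is whether a non-aromatic group on the carbonyl carbon, such as a piperidine or a carboxylic acid, would stay level with compound 2 and compound 3. From the compounds shown here alone, whether the small step holds for a pyridin-3-yl group also remains open.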